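This account rests on a few compounds, and the source may have more. Where it says the series, first, only, none or still open, it means among the compounds named here.

In a functional assay on K562 cells (Homo sapiens), read by MTT assay, with a stated time of 72 h; a higher number here means a weaker inhibitor, a lower number a stronger inhibitor:
- Compound 1 `COc1ncnc2c1c(-c1ccccc1)cn2[C@@H]1O[C@H](CO)[C@@H](O)[C@H]1O`: > 20000 nM, a limit.
- Compound 2 `COc1ncnc2c1c(-c1cc3ccccc3o1)cn2[C@@H]1O[C@H](CO)[C@@H](O)[C@H]1O`: 13100 nM.
- Compound 3 `CSc1ncnc2c1c(-c1ccccc1)cn2[C@@H]1O[C@H](CO)[C@@H](O)[C@H]1O`: > 20000 nM, a limit.

Among the measured compounds shown here, compound 2 holds the only number in the set. The rest of the series stands at the limit of > 20000 nM in this assay, at which 2 of the 3 values shown sit.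

Compound 4 `CNc1ncnc2c1c(-c1cc3ccccc3o1)cn2[C@@H]1O[C@H](CO)[C@@H](O)[C@H]1O` carries methylamino in place of methoxy on an aromatic carbon.

For the measured compounds named here, the only measured change at this place, a step that the two limits leave unreadable from compound 1 to compound 3, brings methylsulfanyl rather than methylamino. The other measured change, an at least 1.5-fold lower number from compound 1 to compound 2 (0.18 log units; that floor lies within the scatter), replaces phenyl and leaves methoxy untouched. Neither sizes this swap, so no step beyond the scatter is expected in this assay, and no firm direction. The expected step is a 1.5-fold lower number from compound 2 to compound 4 (0.16 log units; within the scatter). For compound 4 the estimated value is 9000 nM, with an expected range of 1500 nM to 20000 nM.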

Compound 4, half-maximal inhibitory concentration: > 20000 nM
Compound 4 was reported as a limit (the forecaster's own chance of this, stated with the estimate: 25%); at least 2.2-fold (0.34 log units) between middle value and limit.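

In this assay, among the compounds shown here, the swap of methoxy for methylamino with 1-benzofuran-2-yl kept gives the first readable step at this place: an at least 1.5-fold higher number from compound 2 to compound 4 (0.18 log units; that floor lies within the scatter). Compound 4 gives > 20000 nM, which is a limit. Methylamino brings a hydrogen-bond donor that methoxy lacks, yet no gain can be read, and compound 2 keeps the only number in the set: the limit of > 20000 nM in this assay, at which 3 of the 4 values shown sit.

From the compounds shown here alone, how large the step to compound 4 really is stays open, as only its floor can be read. Also open, going by these compounds, is whether a primary amine, a dimethylamino group or chlorine at this place, with 1-benzofuran-2-yl kept, would give a number inside the limit.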